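The source may hold more compounds than are shown below. What is called first, only, known or untested is meant among the compounds shown, and "the series" means these compounds.

Of the compounds shown here, three built on one shared core have been measured in a functional assay on HeLa cells (Homo sapiens) for antiproliferative activity, read by CCK-8 assay, with a stated time of 72 h, tested at 8 uM; on this read-out higher numbers stand for a stronger effect at the one concentration tested and lower numbers for a weaker effect. Compound 1 `Nc1ccccc1NC(=O)c1ccc(CSC(=S)N2CCN(Cc3ccccn3)CC2)cc1` gives 61.4%, compound 2 `Nc1ccccc1NC(=O)c1ccc(CSC(=S)N2CCN(c3ccc(Cl)cc3)CC2)cc1` gives 44.8%, and compound 3 `CN(C(=S)SCc1ccc(C(=O)Nc2ccccc2N)cc1)c1cccnc1` gives 70.5%. Compound 2 therefore stands lowest of the three in this assay, with compound 1 nearest to it and compound 3 furthest from it, both gaps being beyond the scatter. Among the measured compounds shown here, the only measured step that bears on the change considered here is a number 16.6 percentage points lower from compound 1 to compound 2 (beyond the scatter), a swap on the same amine nitrogen in a ring.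

Compound 4 `CN1CCN(C(=S)SCc2ccc(C(=O)Nc3ccccc3N)cc2)CC1` has not yet been measured. It differs from compound 2 in one place: methyl in place of 4-chlorophenyl on an amine nitrogen in a ring. For the measured compounds named here, since bringing the 4-chlorophenyl onto that ring nitrogen went with a modest fall from compound 1 to compound 2, removing it for a methyl is expected to give a rise of roughly similar size, though no measured compound carries a methyl on this ring nitrogen and the expectation is therefore loose. The step expected is a number 13.2 percentage points higher from compound 2 to compound 4 (beyond the scatter). Compound 4 is thus estimated at 58%, within a range from 40% to 75%.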

Compound 4, a percentage reported as inhibition, at one concentration (the size of the read-out at that concentration, not a potency): 75.7%
The estimate for compound 4 lay 17.7 percentage points below the measured number; measured number above the stated range.
By their numbers in this assay, from the lowest: compound 2; then compounds 1, 3 and 4 (each within the scatter of the next, the first and the last beyond it).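

In this assay the ring nitrogen proves far more sensitive to its substituent than the first step showed: methyl in place of 4-chlorophenyl gives a number 30.9 percentage points higher from compound 2 to compound 4 (beyond the scatter) as a large step, and cutting the (pyridin-2-yl)methyl group back to methyl gives a number 14.3 percentage points higher from compound 1 to compound 4 (beyond the scatter) as a modest one, so that on this ring nitrogen the methyl of compound 4 stands above both larger groups. Exchanging the methyl(pyridin-3-yl)amino group on the thiocarbonyl carbon for 4-methylpiperazin-1-yl gives a number 5.2 percentage points higher from compound 3 to compound 4 (within the scatter) and so separates these two groups by nothing that can be read. Nothing measured here accounts for these steps.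

Still open, going by these compounds, is whether a bare hydrogen, an ethyl or a longer chain on this ring nitrogen would hold the number. A plain benzyl group there would show whether the pyridine nitrogen of compound 1 matters at all.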